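A few compounds are considered here, and "the series" means these few. Any claim that something is new, unique, unknown or untested is made for them only; others in the source may bear on it.

For the measured compounds named here, the three compounds measured so far share one core and differ at two places. Compound 1 `C=CC1=C(C(=O)NCc2ccc(C)cc2)C(c2ccc(OC)cc2)OC1` gives 43100 nM in a functional assay on QGY7701 cells (Homo sapiens) for cytotoxicity, read by MTT assay, with a stated time of 24 h; on this read-out higher numbers stand for weaker inhibition and lower numbers for stronger inhibition. Compound 2 `C=CC1=C(C(=O)NCCC)C(c2ccc(Cl)c(Cl)c2)OC1` gives 31300 nM in this assay. Compound 3 `C=CC1=C(C(=O)NCc2ccc(C)cc2)C(c2ccc(F)cc2)OC1` gives 62100 nM in this assay, the highest of the three numbers, though its gap to compound 1 and its gap to compound 2 both lie within the scatter. Going by the values given here, the one single-place step available, a 1.4-fold higher number from compound 1 to compound 3 (0.16 log units; within the scatter), is likewise within the scatter. Compound 4 `C=CC1=C(C(=O)NCc2ccccc2)C(c2ccc(F)cc2)OC1` differs from compound 3 in one place: hydrogen in place of methyl on an aromatic carbon. Among the compounds with values here, no measured step isolates this change; compound 2 differs from compound 3 at more than one place and so offers no single-place comparison, and all three numbers sit within the scatter of one another. Compound 4 is therefore expected to remain within the scatter of compound 3, with an expected step of a 1.0-fold lower number from compound 3 to compound 4 (0.01 log units; within the scatter). The estimate for compound 4 is 60000 nM, with a range from 25000 nM to 150000 nM.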

Compound 4, half-maximal inhibitory concentration: 67600 nM
Compound 4: middle estimate off by 1.1-fold (0.05 log units), on the low side; measured number inside the range.
By their numbers in this assay, from the lowest: compounds 2, 1, 3 and 4 (each within the scatter of the next, the first and the last beyond it).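

In this assay the change from 4-methylbenzyl to benzyl gives a step (a 1.1-fold higher number from compound 3 to compound 4 (0.04 log units; within the scatter)) that is within the scatter, so removing this methyl from an aromatic carbon, para to a large group, leaves no measurable mark in this pair. For the compounds shown here, the earlier single-place step concerned only fluoro and methoxy on the other aromatic ring, whereas this result is the first reading at the methyl position. No evidence on the cause accompanies this result.

Going by these compounds, it remains open whether an amine or a carboxylic acid at this position would give a step beyond the scatter. On these data alone, it is also open whether the change from methyl to hydrogen would give a similar step with methoxy in place of fluoro on the other aromatic ring.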